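The source may report more compounds than this note shows. Statements on the series, on what has been measured and on what is new or still open speak of the compounds shown alone.

Measured so far in a functional assay on MDA-MB-231 cells (Homo sapiens) for antiproliferative activity, read by fluorescence and SYBR Green assay, with a stated time of 24 h; on this read-out lower numbers stand for stronger inhibition and higher numbers for weaker inhibition:
- compound 1 `COc1ccc2c(c1)CCCN2S(=O)(=O)c1ccc(N2CCCC2=O)cc1`: 20 nM
- compound 2 `CN1CCN(S(=O)(=O)c2ccc(N3CCCC3)cc2)c2ccccc21`: 16 nM

Compound 1 gives the higher of the two numbers in this assay, but its gap to compound 2 lies within the usual scatter of repeated measurements, so the two values show no difference that can be read as a ranking.

Compound 3 `CC(C)(C)c1ccc2c(c1)CCCN2S(=O)(=O)c1ccc(N2CCCC2=O)cc1` has not yet been measured in this assay. Relative to compound 1 it carries a change on the fused core: tert-butyl in place of methoxy on an aromatic carbon, with no change in hydrogen-bond donors and the loss of one acceptor. Within the data shown here, no measured pair in the set probes this kind of exchange, so no step can be taken as a guide. The expectation is a small step from compound 1 to compound 3, not clearly beyond the scatter, with the direction uncertain. Compound 3 is therefore expected at about 30 nM in this assay, within a range of 10 nM to 90 nM, which means an estimated step of a 1.5-fold higher number from compound 1 to compound 3 (0.18 log units; within the scatter).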

Compound 3, half-maximal inhibitory concentration: 608 nM
Compound 3: the middle estimate sits 20-fold (1.31 log units) below what was measured, outside the stated range (above it).
By their numbers in this assay, from the lowest: compounds 2 and 1 (each within the scatter of the next); then compound 3.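

The aromatic carbon of the shared core, meta to a fused ring and para to a fused ring, is not indifferent to its substituent in this assay: tert-butyl in place of methoxy gives a 30-fold higher number from compound 1 to compound 3 (1.48 log units; beyond the scatter). The exchange replaces 2 heavy atoms and 1 hydrogen-bond acceptor with 4 heavy atoms and 0 hydrogen-bond acceptors, so the two counts change together and this single pair cannot separate them. No measured evidence bears on the reason for this step.

Open, from the compounds shown here alone, is whether the outcome follows the oxygen of methoxy or the added carbons of tert-butyl. Hydrogen, methyl, ethoxy or hydroxyl at this carbon would bear on that question, and the compounds shown include none of these.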